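A few compounds are considered here, and "the series" means these few. Any claim that something is new, unique, unknown or untested is made for them only; others in the source may bear on it.

Measured compounds:
compound 1 `O=C(CSc1nnc(-c2ccncc2)o1)N/N=C/c1ccc(Cl)cc1` — 15300 nM
compound 2 `O=C(CSc1nnc(-c2ccncc2)o1)N/N=C/c1ccc([N+](=O)[O-])cc1` — 31800 nM
compound 3 `O=C(CSc1nnc(-c2ccncc2)o1)N/N=C/c1cccc(F)c1` — 24900 nM

All three share one core and differ only in the aromatic ring attached to the carbon with a double bond to nitrogen. In a functional assay on MCF7 cells (Homo sapiens) for cytotoxicity, read by MTT assay, with a stated time of 48 h (on this read-out higher numbers stand for weaker inhibition and lower numbers for stronger inhibition), compound 2 gives the highest of the three numbers. Its gap to compound 3 is within the scatter, as a 1.3-fold lower number from compound 2 to compound 3 (0.11 log units; within the scatter) shows, so the only real difference seen so far is a 2.1-fold higher number from compound 1 to compound 2 (0.32 log units; beyond the scatter); compound 1 stands as the strongest of the set by that one step alone.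

Compound 4 `COc1cc(/C=N/NC(=O)CSc2nnc(-c3ccncc3)o2)ccc1O` is not yet measured. It differs from compound 2 in that ring: 4-hydroxy-3-methoxyphenyl in place of 4-nitrophenyl on a carbon with a double bond to nitrogen

Among the compounds with values here, two steps bear on this change, both swapping the ring on the same carbon: a 2.1-fold higher number from compound 1 to compound 2 (0.32 log units; beyond the scatter) and a 1.3-fold lower number from compound 2 to compound 3 (0.11 log units; within the scatter). Neither is large, and the whole series sits in a narrow band, so the ring swap in this assay has so far moved numbers little. A small move toward a lower number, at most about the size of the step from compound 1 to compound 2, is the most that these data support, and a result within the scatter is just as likely.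

For compound 4 the estimated value is 20000 nM, with a range from 8000 nM to 50000 nM; this expected step is a 1.6-fold lower number from compound 2 to compound 4 (0.20 log units; within the scatter).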

Compound 4, half-maximal inhibitory concentration: 3780 nM
Estimate against measurement, compound 4: 5.3-fold (0.72 log units) above; measured number outside the range, below it.
By their numbers in this assay, from the lowest: compound 4; then compounds 1, 3 and 2 (each within the scatter of the next, the first and the last beyond it).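

Within the data shown here, the ring on the carbon with a double bond to nitrogen can matter far more in this assay than the earlier compounds suggested, since 4-hydroxy-3-methoxyphenyl gives an 8.4-fold lower number from compound 2 to compound 4 (0.92 log units; beyond the scatter) and a 6.6-fold lower number from compound 3 to compound 4 (0.82 log units; beyond the scatter) and also a 4.0-fold lower number from compound 1 to compound 4 (0.61 log units; beyond the scatter) and all three steps lie beyond the scatter. Among these compounds, compound 4 is therefore the strongest of the set, whereas the earlier ring swaps gave only one step beyond the scatter, and a modest one. Compared with 4-nitrophenyl, the entering group has the same number of heavy atoms and hydrogen-bond acceptors and adds a hydrogen-bond donor, but no measurement here explains why the number falls.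

Whether the hydroxy group, the methoxy group or the two together account for this fall stays open, and a 4-hydroxyphenyl or a 3-methoxyphenyl ring on the same carbon would help to separate them. Also open, on these data alone, is whether a different group on the ring, such as an amine or a carboxylic acid, would shift the number in the same way.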